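The compounds below may be only part of what the source reports. "The series", "measured", "known", "first", "only" and "open" are said of these compounds alone.

In a functional assay on SK-MEL-28 cells (Homo sapiens) for inhibition (a higher number here means a weaker inhibitor, a lower number a stronger inhibitor), compound 1 (`CC(=O)Oc1ccc(/C=C/c2ccc3ccccc3c2)cc1`) gives > 5000 nM which is a limit of the assay and not a number. Compound 2 (`FC(F)(F)c1ccc(/C=C\c2ccc3ccccc3c2)cc1`) gives > 5000 nM and this too is a limit. The picture so far is the limit of > 5000 nM in this assay, at which 2 of the 2 values shown sit, and nothing more. Compound 3 (`CN(C)c1ccc(/C=C/c2ccc3ccccc3c2)cc1`) keeps the core of compound 1 but carries dimethylamino in place of acetoxy on an aromatic carbon, para to a large group (dimethylamino in place of acetoxy on an aromatic carbon). For the measured compounds named here, no measured step guides this change, so only a small shift towards stronger inhibition is expected, an estimated at least 1.2-fold lower number from compound 1 to compound 3 (0.09 log units; that floor lies within the scatter) in all. Compound 3 is estimated at 4000 nM with 1000 nM to 10000 nM as the expected range.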

Compound 3, half-maximal inhibitory concentration: 3660 nM
The estimate for compound 3 lay 1.1-fold (0.04 log units) above the measured number; the measured number falls inside the stated range.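

In this assay, compound 3 gives a readable number, and it shows that dimethylamino on this aromatic carbon, para to a large group, brings the value within the range the assay can report. Compound 1 gives > 5000 nM, which is a limit and not a number. From the compounds shown here alone, replacing acetoxy with dimethylamino therefore gives only a floor for the change, an at least 1.3-fold lower number from compound 1 to compound 3 (0.13 log units; that floor lies within the scatter), and its true size remains unknown.

Going by these compounds, whether a primary amine, a carboxylic acid or a longer chain here would lower the number further remains open. Little can yet be ranked: the limit of > 5000 nM in this assay, at which 2 of the 3 values shown sit.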